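This account rests on a few compounds, and the source may have more. Where it says the series, first, only, none or still open, it means among the compounds named here.

Measured compounds:
Compound 1 `NC(=O)c1ccc(-c2cnc(C(=O)CCCCCCc3ccccc3)o2)nc1` — 1.2 nM
Compound 2 `O=C(CCCCCCc1ccccc1)c1ncc(-c2ccncn2)o1` — 2.3 nM
Compound 3 `CN1CCN(C(=O)c2cnc(C(=O)CCCCCCc3ccccc3)o2)CC1` — 80 nM

In an assay (Rattus norvegicus) for inhibition of Fatty-acid amide hydrolase 1 (Homo sapiens) (on this read-out higher numbers stand for weaker inhibition and lower numbers for stronger inhibition), compound 3 gives the highest number of the three, with compound 2 a step of a 35-fold higher number from compound 2 to compound 3 (1.54 log units; beyond the scatter) away and compound 1 a step of a 67-fold higher number from compound 1 to compound 3 (1.82 log units; beyond the scatter) away. Compound 4 `O=C(CCCCCCc1ccccc1)c1ncc(C(=O)N2CCOCC2)o1` differs from compound 3 by morpholin-4-yl in place of 4-methylpiperazin-1-yl on a carbonyl carbon. Among the measured compounds shown here, both measured steps that reach compound 3 replace an aromatic ring with an amide-type group; no measured step swaps one such amide group for another, so they say little about the size of this change. The expectation for compound 4 in this assay is therefore a number close to that of compound 3, with no change at the digits printed from compound 3 to compound 4 (within the scatter) and no step beyond the scatter, giving an estimate of 80 nM with a range from 25 nM to 250 nM.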

Compound 4, inhibition constant: 24 nM
The estimate for compound 4 lay 3.3-fold (0.52 log units) above the measured number; the whole stated range lies above it.
By their numbers in this assay, from the lowest: compounds 1 and 2 (each within the scatter of the next); then compound 4; then compound 3.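

In this assay, the group on the carbonyl carbon matters even among amide-type groups: morpholin-4-yl in place of 4-methylpiperazin-1-yl gives a 3.3-fold lower number from compound 3 to compound 4 (0.52 log units; beyond the scatter), a modest step beyond the scatter. The gain stays partial, with a 10-fold higher number from compound 2 to compound 4 (1.02 log units; beyond the scatter) and a 20-fold higher number from compound 1 to compound 4 (1.30 log units; beyond the scatter), so the (morpholin-4-yl)carbonyl group remains well behind both aromatic rings. Nothing measured here accounts for this difference. Still open, on these data alone, is where a piperidin-1-yl or dimethylamino group on the same carbonyl carbon would fall, and whether any such amide could match compound 1 or compound 2.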